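Amide variation and solubility in an isopropyl ester series

The source may report more compounds than this note shows. Statements on the series, on what has been measured and on what is new or still open speak of the compounds shown alone.

Measured so far in a physicochemical assay for solubility, at pH 7.4; a higher number here means a more soluble compound, a lower number a less soluble compound:
compound 1 `CC(C)OC(=O)C1CN(C(=O)c2cccc(Cl)c2)CC(C)(C)c2cc(C#N)[nH]c21`: 17 ug/mL
compound 2 `CC(C)OC(=O)C1CN(C(=O)C2CCCCC2)CC(C)(C)c2cc(C#N)[nH]c21`: for compound 2 the assay reports only a limit, > 100 ug/mL
compound 3 `CC(C)OC(=O)C1CN(C(=O)c2ccc(C#N)cc2)CC(C)(C)c2cc(C#N)[nH]c21`: 21 ug/mL

Compound 1 sits lowest of the two numbers; its nearest neighbour is compound 3, and a 1.2-fold higher number from compound 1 to compound 3 (0.09 log units; within the scatter), so the two cannot be told apart. Among the measured compounds shown here, the one clear step is an at least 5.8-fold higher number from compound 1 to compound 2 (0.76 log units; beyond the scatter), which runs up to the limit (the limit of > 100 ug/mL in this assay, at which 1 of the 3 values shown sits); seen the other way, an at least 4.7-fold lower number from compound 2 to compound 3 (0.67 log units; beyond the scatter).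

Compound 4 `CC(C)OC(=O)C1CN(C(=O)C2CCOCC2)CC(C)(C)c2cc(C#N)[nH]c21` differs from compound 1 as follows: oxan-4-yl in place of 3-chlorophenyl on a carbonyl carbon. For the measured compounds named here, of the measured steps, the one from compound 1 to compound 2 is the closest precedent, since it also exchanges the 3-chlorophenyl on the carbonyl carbon for a non-aromatic ring; the two aromatic replacements (compound 1 to compound 3) gave nothing beyond the scatter. A rise in this assay is therefore expected for compound 4, a 5.3-fold higher number from compound 1 to compound 4 (0.72 log units; beyond the scatter), possibly again reaching the limit. Compound 4 is estimated at 90 ug/mL, with a range of 40 ug/mL to 200 ug/mL.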

Compound 4, solubility: > 100 ug/mL
Compound 4: only a limit was reported; the forecaster's own chance of this, stated with the estimate: 45%; middle value at least 1.1-fold (0.04 log units) from the limit.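

In this assay, a second non-aromatic ring on the carbonyl carbon goes with the same kind of rise as cyclohexyl in compound 2: an at least 5.8-fold higher number from compound 1 to compound 4 (0.76 log units; beyond the scatter), and an at least 4.7-fold higher number from compound 3 to compound 4 (0.67 log units; beyond the scatter). The rise is therefore not confined to cyclohexyl, as oxan-4-yl, with its one hetero atom and one hydrogen-bond acceptor, also gives it, and among the compounds shown none goes against this split between aromatic and non-aromatic rings. Compound 4 gives > 100 ug/mL, which is a limit of the assay and not a number: the limit of > 100 ug/mL in this assay, at which 2 of the 4 values shown sit.

The steps between compound 2 and compound 4 cannot be read, so any difference between oxan-4-yl and cyclohexyl in this assay remains unresolved. From the compounds shown here alone, whether a piperidin-4-yl ring with its amine, or an open alkyl chain, on the same carbonyl carbon would behave like these two rings also stays open.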